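This account rests on a few compounds, and the source may have more. Where it says the series, first, only, none or still open, it means among the compounds named here.

For the measured compounds named here, compound 2, `S=c1oc(-c2ccc3c(c2)OCCO3)nn1CN1CCN(c2ccccc2Cl)CC1`, is the only compound with a number in a functional assay on HepG2 cells (Homo sapiens) for antiproliferative activity, read by MTT assay, with a stated time of 48 h (a higher number here means a weaker inhibitor, a lower number a stronger inhibitor), where compound 2 gives 11400 nM. Compound 1, `S=c1oc(-c2ccc3c(c2)OCCO3)nn1CN1CCN(c2cccc(Cl)c2)CC1`, returns in this assay only a limit, > 50000 nM, as the limit of > 50000 nM in this assay, at which 1 of the 2 values shown sits, records. Going by the values given here, the step of an at least 4.3-fold lower number from compound 1 to compound 2 (0.64 log units; beyond the scatter) is the single measured change, and it moves a chlorine on the phenyl ring rather than swapping the group itself. Compound 3, `O=[N+]([O-])c1ccc(N2CCN(Cn3nc(-c4ccc5c(c4)OCCO5)oc3=S)CC2)cc1`, differs from compound 2 by 4-nitrophenyl in place of 2-chlorophenyl on an amine nitrogen in a ring. Among the compounds with values here, no measured step tests such an exchange, so only a weak expectation is possible. For compound 3 the expected change is a 1.3-fold higher number from compound 2 to compound 3 (0.12 log units; within the scatter). Compound 3 is thus estimated at 15000 nM, within 4000 nM to 50000 nM.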

Compound 3, half-maximal inhibitory concentration: 29500 nM
Beside the measured number, compound 3's estimate is 2.0-fold (0.29 log units) below it; the measured number falls inside the stated range.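

Replacing the group itself, rather than only moving a chlorine, also shifts the result at this position, giving a 2.6-fold higher number from compound 2 to compound 3 (0.41 log units; beyond the scatter). Compound 1 remains a limit of the assay, not a number: the limit of > 50000 nM in this assay, at which 1 of the 3 values shown sits. Its comparison gives an at least 1.6-fold lower number from compound 1 to compound 3 (0.22 log units; that floor lies within the scatter), so that floor does not set 4-nitrophenyl apart from 3-chlorophenyl. Still open, as far as these compounds go, is whether a phenyl ring carrying an amine or a carboxylic acid on the amine nitrogen in a ring would give a lower number in this assay. From the compounds shown here alone, a benzyl group in place of the phenyl ring is equally open.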